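This account rests on a few compounds, and the source may have more. Where it says the series, first, only, none or still open, it means among the compounds named here.

In a functional assay on MV4-11 cells (Homo sapiens) for antiproliferative activity, read by CCK-8 assay, with a stated time of 72 h (on this read-out lower numbers stand for stronger inhibition and higher numbers for weaker inhibition), compound 1 (`CC(C)Oc1ccc(C(C)(C)O)cc1-c1cn(C)c(=O)c2[nH]c(C(=O)NCc3ccc(C(=O)Nc4ccccc4N)cc3)cc12`) gives 40 nM and compound 2 (`CC(C)Oc1ccccc1-c1cn(C)c(=O)c2[nH]c(C(=O)NCc3ccc(C(=O)Nc4ccccc4N)cc3)cc12`) gives 130 nM as the higher of the two numbers. Compound 3 (`Cn1cc(-c2ccc(F)cc2)c2cc(C(=O)NCc3ccc(C(=O)Nc4ccccc4N)cc3)[nH]c2c1=O`) has not yet been measured. Its difference from compound 2 (4-fluorophenyl in place of 2-isopropoxyphenyl on an aromatic carbon) is 4-fluorophenyl in place of 2-isopropoxyphenyl on an aromatic carbon, ortho to a fused ring. Going by the values given here, the one measured step that bears on this is modest: a 3.3-fold higher number from compound 1 to compound 2 (0.51 log units; beyond the scatter) when hydrogen takes the place of 1-hydroxy-1-methylethyl on an aromatic carbon. Among the compounds with values here, no measured compound carries 4-fluorophenyl, so that step guides the size only loosely and the direction is uncertain. A step of similar modest size toward a higher number is expected (a 2.2-fold higher number from compound 2 to compound 3 (0.33 log units; beyond the scatter)) in this assay on this limited evidence. Compound 3 is estimated at 280 nM with an expected range from 90 nM to 800 nM overall.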

Compound 3, half-maximal inhibitory concentration: 220 nM
Compound 3: the middle estimate sits 1.3-fold (0.10 log units) above what was measured; the measured number falls inside the stated range.
By their numbers in this assay, from the lowest: compound 1; then compounds 2 and 3 (each within the scatter of the next).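

In this assay the exchange of 2-isopropoxyphenyl for 4-fluorophenyl, on the aromatic carbon ortho to a fused ring, gives a 1.7-fold higher number from compound 2 to compound 3 (0.23 log units; within the scatter). Going by these compounds alone, the earlier pair varied only a further substituent on the aryl ring while the isopropoxy group stayed in place, so this is the first view of a change to the aryl group as a whole. At this position, a group with fewer heavy atoms and no hydrogen-bond acceptor leaves the number within the scatter, so for this pair the 2-isopropoxy group is not needed to keep it there.

From the compounds shown here alone, it remains open whether adding 1-hydroxy-1-methylethyl to the 4-fluorophenyl ring would lower the number as it does from compound 2 to compound 1, and how an amine or a carboxylic acid on that ring would read out. Nothing available here offers an explanation for the numbers at this position.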